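A few compounds are considered here, and "the series" means these few. Any claim that something is new, unique, unknown or untested is made for them only; others in the source may bear on it.

Compound 1, whose structure is `CCC[C@@H](O)C1=C(Br)/C(=C/I)OC1=O`, is the reference point here. Going by the values given here, in a functional assay on ZR-75-1 cells (Homo sapiens) for cytotoxicity (a higher number here means that more compound is needed for the effect, a lower number that less compound is needed), compound 1 gives 0.3 ug/mL, the lowest of the two numbers measured so far. The other measured compound, compound 2 with the structure `CCCCC1=C(Br)C(=C(Br)Br)OC1=O`, gives 8.6 ug/mL in this assay, a higher number that lies beyond the usual scatter; the two compounds differ in more than one place, so nothing more than these two values can be read from the pair.

The next compound, compound 3, has the structure `CCC[C@@H](O)C1=C(Br)/C(=C/Cl)OC1=O`. It differs from compound 1 in one place: chloro in place of iodo on a double-bonded chain carbon bound to a double-bonded ring carbon. Among the compounds with values here, no measured pair shows what such a halogen swap does in this assay, so the expected step from compound 1 to compound 3 is a 2.0-fold higher number from compound 1 to compound 3 (0.30 log units; within the scatter), a small move that may stay within the scatter. On that basis the estimate for compound 3 in this assay is 0.6 ug/mL, with a range from 0.15 ug/mL to 2.5 ug/mL.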

Compound 3, concentration for half-maximal effect: 0.4 ug/mL
Compound 3: the middle estimate sits 1.5-fold (0.18 log units) above what was measured, within the range that was stated.
By their numbers in this assay, from the lowest: compounds 1 and 3 (each within the scatter of the next); then compound 2.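

In this assay, the change at this double-bonded chain carbon bound to a double-bonded ring carbon is a 1.3-fold higher number from compound 1 to compound 3 (0.12 log units; within the scatter) and so stays within the scatter. Going by these compounds alone, this is the first pair here that differs in one place, and it shows that chloro and iodo cannot be told apart at this position in this read-out, so iodo is not required for a number this low. No measurement available here explains why the two halogens give such close numbers.

Still open, from the compounds shown here alone, is whether a group that is not a halogen at this place, such as a methyl or a nitrile, would also keep the number this low. Within the data shown here, also open is what a single change elsewhere on the shared core would do, as no pair here isolates one.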